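The source may report more compounds than this note shows. Statements on the series, on what has been measured and on what is new or still open speak of the compounds shown alone.

Measured so far in a functional assay on MDA-MB-436 cells (Homo sapiens) for antiproliferative activity, read by MTT assay, with a stated time of 48 h; a higher number here means a weaker inhibitor, a lower number a stronger inhibitor 

- compound 1 `CN1CCN(c2ccc(-c3cc4c(N5CCN(S(=O)(=O)/C=C/c6ccccc6)CC5)ncnc4s3)cc2)CC1` gives 8670 nM 
- compound 2 `CN1CCN(c2ccc(-c3cc4c(N5CCN(S(=O)(=O)C6CC6)CC5)ncnc4s3)cc2)CC1` gives 10600 nM 

For the measured compounds named here, compound 2 stands level with compound 1, the only other measured compound, and the two cannot be ranked. Compound 3 `CCCNC(=O)N1CCN(c2ncnc3sc(-c4ccc(N5CCN(C)CC5)cc4)cc23)CC1` has not yet been measured. Its difference from compound 2 is propylcarbamoyl in place of cyclopropylsulfonyl on an amine nitrogen in a ring in short, propylcarbamoyl in place of cyclopropylsulfonyl on an amine nitrogen in a ring. Going by the values given here, one measured step touches this same place, a 1.2-fold higher number from compound 1 to compound 2 (0.09 log units; within the scatter) and it stayed within the scatter. That step kept the sulfonyl, while compound 3 loses it, so it is only a loose guide. Among the compounds with values here, no measured pair shows this exact swap. No step beyond the scatter is expected in this assay, and the estimated move is a 1.2-fold lower number from compound 2 to compound 3 (0.07 log units; within the scatter) with wide uncertainty. For compound 3 the estimated value is 9000 nM with an expected range of 2500 nM to 25000 nM in this test.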

Compound 3, half-maximal inhibitory concentration: 12400 nM
For compound 3 the middle estimate is 1.4-fold (0.14 log units) below the measured one, within the range that was stated.
By their numbers in this assay, from the lowest: compounds 1, 2 and 3 (each within the scatter of the next).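

In this assay, propylcarbamoyl in place of cyclopropylsulfonyl on the ring amine nitrogen gives a 1.2-fold higher number from compound 2 to compound 3 (0.07 log units; within the scatter), and propylcarbamoyl in place of (2-phenylethenyl)sulfonyl gives a 1.4-fold higher number from compound 1 to compound 3 (0.16 log units; within the scatter). For the compounds shown here, the earlier step changed only the group carried by the sulfonyl, whereas these steps remove the sulfonyl itself and bring in a hydrogen-bond donor, and still no step goes beyond the scatter. No supporting measurement is available to explain this flat result.

From the compounds shown here alone, it remains open whether a carboxylic acid or a longer chain ending in an amine on this nitrogen would produce a step beyond the scatter. The shared core is also the same in all three compounds, so these steps cannot show whether this position would behave the same way with a different core.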